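The source may hold more compounds than are shown below. What is called first, only, known or untested is meant among the compounds shown, and "the series" means these compounds.

Compound 3, `O=C(CCCCCCc1ccccc1)c1ncon1`, shows the highest number of the three measured compounds in an assay for inhibition of Fatty-acid amide hydrolase 1 (Rattus norvegicus), at pH 9.0 (a higher number here means a weaker inhibitor, a lower number a stronger inhibitor), at 7 nM. Compound 1, `O=C(CCCCCCc1ccccc1)c1ncno1`, gives 1 nM, and the step of a 7.0-fold higher number from compound 1 to compound 3 (0.85 log units; beyond the scatter) is modest. Among the measured compounds shown here, compound 2, `COC(=O)c1cccc(-c2noc(C(=O)CCCCCCc3ccccc3)n2)n1`, gives 3 nM; no step between compound 1 and compound 2 is given, so their two values stand on their own. Compound 4, `O=C(CCCCCCc1ccccc1)c1noc(-c2ccco2)n1`, carries furan-2-yl in place of hydrogen on an aromatic carbon. For the measured compounds named here, no measured step covers the same change; compound 2 shows that an aryl group on the core of compound 1 leaves the number close to that of compound 1. Compound 4 is therefore expected to stay near compound 3 in this assay, the step of a 1.4-fold lower number from compound 3 to compound 4 (0.15 log units; within the scatter) being within or only slightly beyond the scatter, with an estimate of 5 nM and a range from 1.5 nM to 20 nM.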

Compound 4, inhibition constant: 8.5 nM
For compound 4 the middle estimate is 1.7-fold (0.23 log units) below the measured one, within the range that was stated.
By their numbers in this assay, from the lowest: compound 1; then compound 2; then compounds 3 and 4 (each within the scatter of the next).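

In this assay furan-2-yl in place of hydrogen on an aromatic carbon, next to the ring nitrogen and next to the ring oxygen, brings a 1.2-fold higher number from compound 3 to compound 4 (0.08 log units; within the scatter) and so shows that this place on the core of compound 3 takes a five-membered aromatic ring without a change beyond the scatter. Nothing shown gives a reason for this result. The compounds shown leave open whether an amine, a carboxylic acid or a phenyl ring at this place would give the same reading.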